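Working notes: from compound 1 to compound 3

A few compounds are considered here, and "the series" means these few. Any claim that something is new, unique, unknown or untested is made for them only; others in the source may bear on it.

Compound 1 `O=C(O)CCCCC(CCSC(=O)c1ccccc1)SC(=O)c1ccccc1` gives 2.68%
Compound 2 `COc1ccc(NC(=O)CCCCC(S)CCS)cc1` gives 8.93%

Both values come from a functional assay on KB cells (Homo sapiens) for inhibition, read by MTT assay, with a stated time of 24 h, tested at 10 ug/mL; on this read-out lower numbers stand for less inhibition of growth and higher numbers for more inhibition of growth at the one concentration tested. Compound 1 stands level with compound 2 here, since their two values lie within the usual scatter of each other. Both show little inhibition of growth at the one concentration tested, and the pair gives no measured step to reason from.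

Compound 3 `O=C(CCCCC(CCSC(=O)c1ccccc1)SC(=O)c1ccccc1)Nc1ccc(Cl)cc1` has not yet been measured in this assay. It differs from compound 1 by (4-chlorophenyl)amino in place of hydroxy on a carbonyl carbon. The rest of compound 1 is kept.

For the measured compounds named here, with compound 1 at 2.68% and no measured compound far from it, nothing supports expecting a large change. The estimated step of a number 9.3 percentage points higher from compound 1 to compound 3 (within the scatter) is expected to be modest and toward more inhibition of growth, possibly no larger than the usual scatter. For compound 3 the expected value is 12%, with an estimated range from 2% to 32%.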

Compound 3, percent growth inhibition at one concentration: 10.6%
Beside the measured number, compound 3's estimate is 1.4 percentage points above it; low and high end bracket the measured number.
By their numbers in this assay, from the lowest: compounds 1, 2 and 3 (each within the scatter of the next).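

For the compounds shown here, this is the first step that can be read at one place: in this assay, (4-chlorophenyl)amino in place of hydroxy on a carbonyl carbon gives a number 7.9 percentage points higher from compound 1 to compound 3 (within the scatter), with the rest of compound 1 kept. The position therefore takes the larger (4-chlorophenyl)carbamoyl group in place of carboxy with no step beyond the scatter, and compound 3 at 10.6% still shows little inhibition of growth at the one concentration tested. No measurement shown here bears on why the step has this size.

Because the compounds shown offer only this one change at this position, they leave open whether the chlorine atom or the aromatic ring has any bearing on the read-out, which a comparison of phenylamino, a methyl ester or a short alkylamino group at the same carbonyl carbon would address. Compound 2 differs from compound 3 in more than one place, so the free thiol groups and the 4-methoxyphenyl amide cannot be judged separately, and a series of concentrations would be needed to show anything beyond this single-concentration reading.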